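A Nitro Group Replaces Methyl on the Benzyl Arm

The source may hold more compounds than are shown below. What is called first, only, known or untested is meant among the compounds shown, and "the series" means these compounds.

Compound 2 `COC(=O)[C@H](CCSC)NC(=O)c1ccc(NCc2cncn2Cc2cccc(C)c2)cc1-c1ccccc1` has been examined in a functional assay on NIH3T3 cells (Mus musculus); a higher number here means that more compound is needed for the effect, a lower number that less compound is needed. In this assay compound 2 gives > 10 uM, which is a limit of the measurement and not a number. Its close relative compound 1 `COC(=O)[C@H](CCSC)NC(=O)c1ccc(NCc2cncn2Cc2ccc(C)cc2)cc1-c1ccccc1` stands at the same kind of boundary: in this assay compound 1 gives > 10 uM, again a limit rather than a number. The step that the two limits leave unreadable from compound 1 to compound 2 therefore cannot be read, since both ends sit at the limit of > 10 uM in this assay, at which 2 of the 2 values shown sit.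

Compound 3 `COC(=O)[C@H](CCSC)NC(=O)c1ccc(NCc2cncn2Cc2ccc([N+](=O)[O-])cc2)cc1-c1ccccc1` differs from compound 2 by 4-nitrophenyl in place of 3-methylphenyl on a saturated chain carbon bound to an aromatic nitrogen. For the measured compounds named here, the only measured step that could bear on this change is the one already described, and its size is not readable, so no direction and no magnitude can be taken from it. With both known compounds resting at a limit, compound 3 is expected to remain at that limit as well. Compound 3 is accordingly estimated at 15 uM, with a range from 5 uM to 60 uM. The expected step that the limit leaves unreadable from compound 2 to compound 3 amounts to no change beyond the scatter.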

Compound 3, concentration for half-maximal effect: > 10 uM
Compound 3: no number, only a limit; the forecaster's own chance of this, stated with the estimate: 80%; the middle value does not contradict the limit.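

In this assay compound 3 gives > 10 uM, which is a limit and not a number. No new step can be read between compound 3 and compound 1 or compound 2, since all three rest at the same boundary: the limit of > 10 uM in this assay, at which 3 of the 3 values shown sit. The compounds shown leave open whether 4-nitrophenyl, 3-methylphenyl and 4-methylphenyl differ at all in this read-out.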